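A few compounds are considered here, and "the series" means these few. Any claim that something is new, unique, unknown or untested is made for them only; others in the source may bear on it.

Compound 1, `O=C(NO)c1cc2ccn(Cc3cccc(Cl)c3F)c2cn1`, in an ADME assay on CEM-SS cells (Homo sapiens) for cytotoxicity, read by XTT assay (a lower number here means that less compound is tolerated, a higher number that more compound is tolerated), gives > 320000 nM, a limit of the assay.
Compound 2, `O=C(NO)c1cc2ccn(Cc3c(F)ccc(Cl)c3F)c2cn1`, gives > 1000 nM, also a limit.
Compound 3, `NC(=O)c1cc(Cn2ccc3cc(C(=O)NO)ncc32)ccc1F`, gives > 10000 nM, again a limit.

Compound 1 and compound 2 differ in one place, (hydrogen in place of fluoro on an aromatic carbon). The step that the two limits leave unreadable from compound 2 to compound 1 cannot be read, because the limit of > 1000 nM in this assay, at which 1 of the 3 values shown sits, and the limit of > 320000 nM in this assay, at which 1 of the 3 values shown sits, bound the pair from opposite sides. Compound 3 carries a different substituted ring; how its core differs from that of compound 2 is not broken down here.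

Compound 4, `NC(=O)c1cccc(Cn2ccc3cc(C(=O)NO)ncc32)c1`, has not yet been measured. It stands to compound 3 as compound 1 stands to compound 2: hydrogen in place of fluoro on an aromatic carbon. This is the same kind of change, though the surroundings differ: in compound 2 the departing fluoro sits ortho to a large group, meta to a fluoro group and para to a chloro group, whereas in compound 3 it sits ortho to a carbamoyl group and para to a large group. The measured step offers no readable size, so the expectation for compound 4 rests on compound 3 alone, whose value is only a limit, (the limit of > 10000 nM in this assay, at which 1 of the 3 values shown sits). Compound 4 is expected to tolerate roughly as much compound, a step that the limit leaves unreadable from compound 3 to compound 4. Compound 4 is estimated at 30000 nM, within 8000 nM to 300000 nM.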

Compound 4, half-maximal cytotoxic concentration: > 10000 nM
Compound 4: a limit, no number; the forecaster's own chance of this, stated with the estimate: 70%; the middle value lies beyond the limit too.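

In this assay, compound 3 and compound 4 both end at a limit of the assay, so no step can be read between them: the limit of > 10000 nM in this assay, at which 2 of the 4 values shown sit.

The compounds shown leave open how much of any of them the cells tolerate, and whether hydrogen in place of fluoro on an aromatic carbon changes that tolerance at all.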